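The source may hold more compounds than are shown below. What is called first, only, known or untested is meant among the compounds shown, and "the series" means these compounds.

Measured in an ADME assay on MT4 cells (Homo sapiens) for cytotoxicity, read by MTT assay; a lower number here means that less compound is tolerated, a higher number that more compound is tolerated:
compound 1 `Cc1cc(C)cc(S(=O)(=O)c2c(C(=O)NCc3cccc(F)c3F)[nH]c3ccc(Cl)cc23)c1`: > 51100 nM (a limit)
compound 2 `Cc1cc(C)cc(S(=O)(=O)c2c(C(=O)NCC(=O)NCc3ccncc3)[nH]c3ccc(Cl)cc23)c1`: > 48900 nM (a limit)
compound 3 `Cc1cc(C)cc(S(=O)(=O)c2c(C(=O)NCc3cccc(N)c3)[nH]c3ccc(Cl)cc23)c1`: > 53400 nM (a limit)

Compound 3 stands only at a limit, > 53400 nM, and no number is known for it. Going by the values given here, the two other compounds in this assay are likewise known only by their limits, so no measured compound gives a number to start from.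

Compound 4 `Cc1cc(C)cc(S(=O)(=O)c2c(C(=O)Nc3ccnc(C#N)c3)[nH]c3ccc(Cl)cc23)c1` carries 2-cyanopyridin-4-yl in place of 3-aminobenzyl on an amide-type nitrogen.

The nearest evidence comes from changes to the group on the same amide-type nitrogen: a step that the two limits leave unreadable from compound 1 to compound 3, a step that the two limits leave unreadable from compound 1 to compound 2 and a step that the two limits leave unreadable from compound 2 to compound 3. None of these has a readable size, and each replaces a group on a saturated chain carbon, not the whole group on the nitrogen. With compound 3 at > 53400 nM, no step beyond the scatter and no direction is expected in this assay. The expected step is an at least 1.0-fold lower number from compound 3 to compound 4 (0.02 log units; that floor lies within the scatter). Compound 4 is expected to be reported as a limit as well. For compound 4 the estimated value is 50000 nM, within an estimated range from 15000 nM to 60000 nM.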

Compound 4, half-maximal cytotoxic concentration: 6840 nM
For compound 4 the middle estimate is 7.3-fold (0.86 log units) above the measured one; measured number outside the range, below it.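

In this assay, compound 4 is the only compound shown with a number rather than a limit, and its change on the amide-type nitrogen gives an at least 7.8-fold lower number from compound 3 to compound 4 (0.89 log units; beyond the scatter), along with an at least 7.1-fold lower number from compound 2 to compound 4 (0.85 log units; beyond the scatter) and an at least 7.4-fold lower number from compound 1 to compound 4 (0.87 log units; beyond the scatter). Going by these compounds alone, the steps among compounds 1, 2 and 3 cannot be read, so this is the first sign that the group at this position can shift the number beyond the scatter, and all three steps are lower bounds on its size. Nothing shown gives a cause for this drop.

The entering 2-cyanopyridin-4-yl differs from 3-aminobenzyl in its ring nitrogen, its nitrile and the missing chain carbon all at once, so the compounds shown do not say which of these carries the step. A plain pyridin-4-yl, a 3-cyanophenyl or a 2-cyanopyridin-4-ylmethyl group on the same nitrogen would begin to separate them.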